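A few compounds are considered here, and "the series" means these few. Any claim that something is new, unique, unknown or untested is made for them only; others in the source may bear on it.

Working notes on the series. All compounds share one core and differ in the group on an amine nitrogen in a ring. In a functional assay (strain AB) with Danio rerio as the target, read by microscopy, with a stated time of 1 h (a higher number here means that more compound is needed for the effect, a lower number that less compound is needed), compound 1 `NC(=O)c1c(NC(=O)Nc2ccc(Cl)cc2)sc2c1CCN(CC1CCCCC1)C2` gives 1890 nM, compound 2 `NC(=O)c1c(NC(=O)Nc2ccc(Cl)cc2)sc2c1CCN(CC1CCCC1)C2` gives 1830 nM and compound 3 `COCCCN1CCc2c(sc(NC(=O)Nc3ccc(Cl)cc3)c2C(N)=O)C1` gives 2400 nM. These values lie within the scatter of one another, so compound 3 stands level with compound 1 and compound 2.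

The next change leads to compound 4 `CC(C)N1CCc2c(sc(NC(=O)Nc3ccc(Cl)cc3)c2C(N)=O)C1`, with isopropyl in place of 3-methoxypropyl on an amine nitrogen in a ring.

Going by the values given here, three measured steps bear on this change: a 1.0-fold lower number from compound 1 to compound 2 (0.01 log units; within the scatter), a 1.3-fold higher number from compound 1 to compound 3 (0.10 log units; within the scatter) and a 1.3-fold higher number from compound 2 to compound 3 (0.12 log units; within the scatter). Each is within the scatter, so exchanging these groups has not yet moved the number in this assay. Among the compounds with values here, the series offers no direct precedent, however, as none of the measured compounds carries isopropyl, and in each of them the varied group sits on a saturated chain carbon bound to that nitrogen. No step beyond the scatter is therefore expected, and no direction is favoured with confidence.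

The expected step is a 1.1-fold lower number from compound 3 to compound 4 (0.06 log units; within the scatter). For compound 4 the estimated value is 2100 nM, with an expected range from 900 nM to 5000 nM.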

Compound 4, half-maximal effective concentration: 1490 nM
Compound 4: middle estimate off by 1.4-fold (0.15 log units), on the high side; the measured number falls inside the stated range.
By their numbers in this assay, from the lowest: compounds 4, 2, 1 and 3 (each within the scatter of the next).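

Replacing 3-methoxypropyl (5 heavy atoms, 1 hydrogen-bond acceptor) with the smaller isopropyl (3 heavy atoms, 0 hydrogen-bond acceptors) on the amine nitrogen in a ring leaves the result in this assay within the scatter (a 1.6-fold lower number from compound 3 to compound 4 (0.21 log units; within the scatter)), so this position now has a direct reading for a group that lacks the oxygen and is shorter than the earlier ones. Isopropyl, which has no ring, also stays within the scatter of the ring-bearing groups (a 1.2-fold lower number from compound 2 to compound 4 (0.09 log units; within the scatter); a 1.3-fold lower number from compound 1 to compound 4 (0.10 log units; within the scatter)), which extends the flat picture at this position to all four compounds, with none going against it. No supporting measurement is available that could account for this flat picture.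

From the compounds shown here alone, whether a carboxylic acid, an amine at the end of a longer chain, or a benzyl group on this nitrogen would move the number beyond the scatter remains open. Every compound shown also carries the shared core unchanged, so the notes say nothing about how sensitive the number is to changes elsewhere in the structure.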